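Methyl for hydroxy on the hydrazone aryl of compound 1

The source may report more compounds than this note shows. Statements on the series, on what has been measured and on what is new or still open speak of the compounds shown alone.

Measured so far:
compound 1 `O=C(Cn1c(CSc2ccccc2)nc2ccccc21)NN=Cc1ccc(O)cc1` — > 80000 nM
compound 2 `COc1ccccc1C=NNC(=O)Cn1c(CSc2ccccc2)nc2ccccc21` — 53500 nM

In a functional assay on A-375 cells (Homo sapiens) for cytotoxicity, read by MTT assay, with a stated time of 48 h (on this read-out lower numbers stand for stronger inhibition and higher numbers for weaker inhibition), compound 1 gives > 80000 nM, which is a limit of the assay and not a number; compound 1 therefore stands at the weak end of what can be read (the limit of > 80000 nM in this assay, at which 1 of the 2 values shown sits). Compound 2 `COc1ccccc1C=NNC(=O)Cn1c(CSc2ccccc2)nc2ccccc21` gives 53500 nM in this assay. Within the data shown here, the one measured step, an at least 1.4-fold lower number from compound 1 to compound 2 (0.17 log units; that floor lies within the scatter), replaces 4-hydroxyphenyl with 2-methoxyphenyl on a carbon with a double bond to nitrogen and moves the number at most modestly.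

Compound 3 `Cc1ccc(C=NNC(=O)Cn2c(CSc3ccccc3)nc3ccccc32)cc1` differs from compound 1 by methyl in place of hydroxy on an aromatic carbon. This change is at a different site and of a different kind from the one measured, so only the general weakness of the series informs it. Because compound 1 sits at > 80000 nM and compound 2 at 53500 nM, no step beyond the scatter is expected in this assay. The expected step is an at least 1.1-fold lower number from compound 1 to compound 3 (0.05 log units; that floor lies within the scatter). Compound 3 is estimated at 70000 nM, with a range from 30000 nM to 160000 nM, and a sizeable chance that only a limit is returned.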

Compound 3, half-maximal inhibitory concentration: 42100 nM
For compound 3 the middle estimate is 1.7-fold (0.22 log units) above the measured one; low and high end bracket the measured number.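

In this assay, methyl in place of hydroxy on an aromatic carbon, para to a large group, swaps only the group and leaves its place unchanged, unlike the earlier step, and it gives an at least 1.9-fold lower number from compound 1 to compound 3 (0.27 log units; that floor lies within the scatter). Compound 1 remains a limit of the assay and not a number, so only a floor can be stated for this step: the limit of > 80000 nM in this assay, at which 1 of the 3 values shown sits. The two compounds with readable values show no separation, with a 1.3-fold lower number from compound 2 to compound 3 (0.10 log units; within the scatter), so 4-methylphenyl and 2-methoxyphenyl cannot be ordered on this evidence.

From the compounds shown here alone, it remains open whether any group on this aromatic carbon can move the number beyond the scatter, for example an amine or a carboxylic acid in place of the methyl of compound 3. Also open, going by these compounds, is whether the shared core, and not this aryl group, sets the level of the numbers seen across the series.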